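The source may report more compounds than this note shows. Statements on the series, on what has been measured and on what is new or still open speak of the compounds shown alone.

Working notes on the series built around compound 1 `CCCSc1nc(Cl)c2c(n1)N(CCNC(=O)OC(C)(C)C)C(C(=O)N1CCN(C)CC1)N2`, with compound 2 `CCCSc1nc(Cl)c2c(n1)N(Cc1ccccc1)C(C(=O)OCC)N2` and compound 3 `CCCSc1nc(Cl)c2c(n1)N(Cc1ccccc1)C(C(=O)NCCCc1ccccc1)N2` as the other measured members. In a functional assay on PC-3 cells (Homo sapiens) for antiproliferative activity, read by MTT assay, with a stated time of 72 h (a higher number here means a weaker inhibitor, a lower number a stronger inhibitor), compound 1 gives > 64000 nM, which is a limit of the assay and not a number; it is the one case of the limit of > 64000 nM in this assay, at which 1 of the 3 values shown sits. Compound 2 gives 62500 nM and compound 3 gives 12700 nM, so all measured members sit at the weak end of the range. Within the data shown here, the only one-place step measured is a 4.9-fold lower number from compound 2 to compound 3 (0.69 log units; beyond the scatter), a change on a carbonyl carbon, not on the ring nitrogen substituent.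

Compound 4 `CCCSc1nc(Cl)c2c(n1)N(CC1CCCCC1)C(C(=O)N1CCN(C)CC1)N2` is reached from compound 1 by cyclohexyl in place of ((tert-butoxycarbonyl)amino)methyl on a saturated chain carbon bound to a nitrogen on an aromatic ring in a ring. Among the measured compounds shown here, no measured step touches this position, and compound 1 offers only a limit as a starting point, so the expectation rests on the series staying weak throughout. For compound 4 the expected value in this assay is 45000 nM, with a range from 15000 nM to 100000 nM. That estimate corresponds to an expected at least 1.4-fold lower number from compound 1 to compound 4 (0.15 log units; that floor lies within the scatter), which is not expected to lie clearly beyond the scatter.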

Compound 4, half-maximal inhibitory concentration: 12800 nM
For compound 4 the middle estimate is 3.5-fold (0.55 log units) above the measured one; the whole stated range lies above it.
By their numbers in this assay, from the lowest: compounds 3 and 4 (each within the scatter of the next); then compound 2. At a limit, above all of these: compound 1.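

In this assay, cyclohexyl in place of ((tert-butoxycarbonyl)amino)methyl on a saturated chain carbon bound to a nitrogen on an aromatic ring in a ring gives an at least 5.0-fold lower number from compound 1 to compound 4 (0.69 log units; beyond the scatter). Among these compounds, this is the only measured step at this position, and it shows that the read-out moves here with the carbonyl substituent of compound 1 unchanged, whereas the earlier step, a 4.9-fold lower number from compound 2 to compound 3 (0.69 log units; beyond the scatter), lay on a carbonyl carbon. The size of the new step is only a floor, because compound 1 stands at a limit of the assay and not at a number: the limit of > 64000 nM in this assay, at which 1 of the 4 values shown sits.

From the compounds shown here alone, whether the lower number follows from the entering cyclohexyl or from the leaving ((tert-butoxycarbonyl)amino)methyl stays open. A 2-aminoethyl group or a straight hexyl chain in this place would separate the two.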